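From 4-fluorobenzyl to 2-chlorobenzyl on compound 1

A few compounds are considered here, and "the series" means these few. Any claim that something is new, unique, unknown or untested is made for them only; others in the source may bear on it.

Going by the values given here, only two compounds carry numbers so far. In a functional assay on MCF7 cells (Homo sapiens) for cytotoxicity, read by MTT assay, with a stated time of 24 h (on this read-out higher numbers stand for weaker inhibition and lower numbers for stronger inhibition), compound 1 (`Cc1ccc(/C=C2\CN(Cc3cn(Cc4ccc(F)cc4)nn3)C/C(=C\c3ccc(C)cc3)C2=O)cc1`) gives 29000 nM as the highest of the two numbers, which places it on the side of weaker inhibition. Compound 2 (`O=C1/C(=C/c2ccccc2F)CN(Cc2cn(Cc3ccc(F)cc3)nn2)C/C1=C\c1ccccc1F`) gives 6000 nM as its number, lower than that of compound 1 and beyond the usual scatter.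

Compound 3 (`Cc1ccc(/C=C2\CN(Cc3cn(Cc4ccccc4Cl)nn3)C/C(=C\c3ccc(C)cc3)C2=O)cc1`) keeps the core of compound 1 and differs from it in one place: 2-chlorophenyl in place of 4-fluorophenyl on a saturated chain carbon bound to an aromatic nitrogen is the whole change, with 2-chlorophenyl in place of 4-fluorophenyl on a saturated chain carbon bound to an aromatic nitrogen. Among the compounds with values here, no measured pair differs at this place alone, and the data offer no direct guide to the direction of such a change.

The expected outcome is therefore no shift beyond the scatter, with the estimated 1.5-fold lower number from compound 1 to compound 3 (0.16 log units; within the scatter) in this assay as the working figure. For compound 3 the estimated value is 20000 nM with 7000 nM to 55000 nM as the expected range.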

Compound 3, half-maximal inhibitory concentration: 66700 nM
Estimate against measurement, compound 3: 3.3-fold (0.52 log units) below; the whole stated range lies below it.
By their numbers in this assay, from the lowest: compound 2; then compound 1; then compound 3.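

This place on the series is the first shown to respond in this assay: with the core of compound 1 held fixed, 2-chlorophenyl in place of 4-fluorophenyl on a saturated chain carbon bound to an aromatic nitrogen gives a 2.3-fold higher number from compound 1 to compound 3 (0.36 log units; beyond the scatter) as a modest step beyond the scatter, toward weaker inhibition. The read-out is therefore sensitive to this swap of one halogen-bearing phenyl for another, even though the heavy-atom count and the hydrogen-bond donor and acceptor counts of the two groups are the same. No measured finding on either group bears on this step, and the reason for it remains unknown.

With one pair at this place, the change of halogen and the change in its printed ring position cannot be told apart, and 4-chlorobenzyl or 2-fluorobenzyl on the same core would be needed to separate them. As far as these compounds go, it also remains open whether the step holds on other cores, and whether a group of another kind here, such as a plain benzyl, an aminoethyl chain or a carboxylic acid on a longer chain, would move the number toward stronger inhibition.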